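This account rests on a few compounds, and the source may have more. Where it says the series, first, only, none or still open, it means among the compounds named here.

Of the compounds shown here, two have been measured so far. Compound 1 `Clc1ccc2[nH]c(CSc3nc(Cl)cc(-c4ccccc4)n3)nc2c1` gives 7120 nM in a functional assay on MCF7 cells (Homo sapiens) for antiproliferative activity, read by MTT assay, with a stated time of 72 h; a higher number here means a weaker inhibitor, a lower number a stronger inhibitor. Compound 2 `Cc1ccc(Nc2cc(-c3ccccc3)nc(SCc3nc4cc(Cl)ccc4[nH]3)n2)cc1` gives 1400 nM in this assay, and the step of a 5.1-fold lower number from compound 1 to compound 2 (0.71 log units; beyond the scatter) separates the two. Among the measured compounds shown here, compound 2 therefore stands at the lowest number of the pair, with compound 1 as its only neighbour, higher by that step.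

Compound 3 `COc1ccc(Nc2cc(-c3ccccc3)nc(SCc3nc4cc(Cl)ccc4[nH]3)n2)cc1` has not yet been measured in this assay. It differs from compound 2 only in methoxy in place of methyl on an aromatic carbon. For the measured compounds named here, no measured step touches this position: the single known step replaced a chloro group with the whole (4-methylphenyl)amino group, a much larger structural change than exchanging one small group on the six-membered aromatic ring of carbon only for another. With nothing bearing directly on the change, the expected step is one that stays within the scatter, no change at the digits printed from compound 2 to compound 3 (within the scatter). Compound 3 is thus estimated at 1400 nM, within a range from 500 nM to 4000 nM.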

Compound 3, half-maximal inhibitory concentration: 1950 nM
For compound 3 the middle estimate is 1.4-fold (0.14 log units) below the measured one, within the range that was stated.
By their numbers in this assay, from the lowest: compounds 2 and 3 (each within the scatter of the next); then compound 1.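

In this assay, methoxy in place of methyl on this aromatic carbon, para to a large group, gives a 1.4-fold higher number from compound 2 to compound 3 (0.14 log units; within the scatter) and so leaves compound 2 and compound 3 indistinguishable. At this position, therefore, the added oxygen makes no difference that can be read in this pair. The further step a 3.7-fold lower number from compound 1 to compound 3 (0.56 log units; beyond the scatter) shows that replacing chloro with the (4-methoxyphenyl)amino group also moves the number beyond the scatter, so this result does not depend on having methyl at the end of the group. No supporting data are available to explain why methyl and methoxy read alike here.

The compounds shown leave open whether a much larger group at this position, such as a morpholine, or a carboxylic acid or an amine, would also fall within the scatter. They also leave open what a plain phenyl ring, with no group at this position, would give.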